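This account rests on a few compounds, and the source may have more. Where it says the series, first, only, none or still open, it means among the compounds named here.

Two nucleoside analogues have been tested in a functional assay on CEM-DNR-bulk cells (Homo sapiens), read by MTT assay, with a stated time of 72 h; on this read-out lower numbers stand for stronger inhibition and higher numbers for weaker inhibition. Compound 1 `Cc1ncnc2c1c(-c1cccs1)cn2[C@@H]1O[C@H](CO)[C@@H](O)[C@H]1O` reaches only a limit of the assay: in this assay compound 1 gives > 20000 nM, a limit rather than a measured number. Compound 2 `O=c1[nH]cnc2c1c(-c1ccsc1)cn2[C@@H]1O[C@H](CO)[C@@H](O)[C@H]1O` likewise reaches only a limit, since in this assay compound 2 gives > 20000 nM. Going by the values given here, compound 2 thus stands exactly where every value shown stands, namely at the limit of > 20000 nM in this assay, at which 2 of the 2 values shown sit, and no measured step between two compounds exists here. Compound 3 `O=c1[nH]cnc2c1c(-c1ccco1)cn2[C@@H]1O[C@H](CO)[C@@H](O)[C@H]1O` is not yet measured. It differs from compound 2 in one place: furan-2-yl in place of thiophen-3-yl on an aromatic carbon. Among the compounds with values here, with both known compounds at the limit and no measured step to go by, the step of a number no higher from compound 2 to compound 3 (the limit leaves the size open) is expected to be none beyond the usual scatter. Compound 3 is therefore expected to give about 20000 nM in this assay, most probably again as a limit, within a range from 6000 nM to 60000 nM.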

Compound 3, half-maximal inhibitory concentration: > 20000 nM
Compound 3: no number, only a limit; the forecaster's own chance of this, stated with the estimate: 80%; the middle value sits exactly at the limit.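

In this assay compound 3 gives > 20000 nM, a limit and not a number. Going by these compounds alone, with compound 2 also at a limit, no step between compound 2 and compound 3 can be read. The compounds shown leave open whether furan-2-yl and thiophen-3-yl differ in this assay at all.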